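A few compounds are considered here, and "the series" means these few. Any claim that something is new, unique, unknown or untested is made for them only; others in the source may bear on it.

Compound 1 `C=C1CCCC[C@@]23N(C(=O)OCc4ccccc4)CC[C@@]12c1c(C)cc(C)cc1N3C` and compound 2 `C=C1CCCC[C@]23N(C)c4cc(C)cc(C)c4[C@]12CCN3S(=O)(=O)c1ccc(Cl)cc1` share a core and differ only in the group on an amine nitrogen in a ring. Both were tested in a toxicity assay on HeLa cells (Homo sapiens) for cytotoxicity, read by luminescence and CellTiter-Glo, with a stated time of 24 h; on this read-out lower numbers stand for stronger inhibition of growth and higher numbers for weaker inhibition of growth. Compound 1 gives > 64 ug/mL, which is a limit of the assay and not a number. Compound 2 gives > 64 ug/mL, also a limit, and this is the only standing it has.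

Compound 3 `C=C1CCCC[C@@]23N(C(=O)NCc4ccccc4)CC[C@@]12c1c(C)cc(C)cc1N3C` carries benzylcarbamoyl in place of (4-chlorophenyl)sulfonyl on that same nitrogen: benzylcarbamoyl in place of (4-chlorophenyl)sulfonyl on an amine nitrogen in a ring. Among the measured compounds shown here, the one measured step that bears on this change, a step that the two limits leave unreadable from compound 1 to compound 2, has no readable size, and the evidence so far is the limit of > 64 ug/mL in this assay, at which 2 of the 2 values shown sit. It offers no direction, so no step beyond the scatter is expected in this assay. The expected step is a number no higher from compound 2 to compound 3 (the limit leaves the size open). For compound 3 the estimated value is 64 ug/mL, with an expected range from 30 ug/mL to 128 ug/mL.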

Compound 3, concentration for 50% growth inhibition: > 64 ug/mL
Compound 3: a limit, no number; the forecaster's own chance of this, stated with the estimate: 75%; the middle value lies on the limit itself.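

No step can be read among compound 1, compound 2 and compound 3, since each gives a limit and not a number in this assay: the limit of > 64 ug/mL in this assay, at which 3 of the 3 values shown sit.

The compounds shown leave open whether the groups on that amine nitrogen in a ring differ in their effect on growth of these cells.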